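Cytotoxicity notes on the triazole ester series: compound 3 to compound 4

The source may hold more compounds than are shown below. What is called first, only, known or untested is meant among the compounds shown, and "the series" means these compounds.

Three compounds precede the one at issue: compound 1 (`Cc1nc2ccccc2c(-c2ccccc2)c1C(=O)OCc1cn(-c2ccc(F)cc2)nn1`), compound 2 (`Cc1nc2ccccc2c(-c2ccccc2)c1C(=O)OCc1cn(Cc2ccc([N+](=O)[O-])cc2)nn1`) and compound 3 (`Cc1nc2ccc(Cl)cc2c(-c2ccccc2)c1C(=O)OCc1cn(-c2ccc(F)cc2)nn1`). Among the measured compounds shown here, in an ADME assay on J774.A1 cells (Mus musculus) for cytotoxicity, read by MTT assay, with a stated time of 48 h (on this read-out higher numbers stand for lower toxicity in this test and lower numbers for higher toxicity in this test), compound 2 gives 42000 nM, the only number available for the series. The entry for compound 1 reads "not determined" (no result reported). The entry for compound 3 reads "not determined" (no result reported), so compound 3 has no single number and no place on the scale, and one further compound shares that position.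

For the measured compounds named here, compound 4 (`Cc1ccc(-n2cc(COC(=O)c3c(C)nc4ccc(Cl)cc4c3-c3ccccc3)nn2)cc1F`) has no measurement yet. The structural change is 3-fluoro-4-methylphenyl in place of 4-fluorophenyl on an aromatic nitrogen. Going by the values given here, no measured step exists between any two compounds here, so the size of this change cannot be calibrated on the series. In this assay no step beyond the usual scatter is expected from this exchange, in either direction, although the missing number for compound 3 leaves nothing to test that expectation against. Among the compounds with values here, the only anchor is compound 2 at 42000 nM, a compound with a different substituent on the same aromatic nitrogen, so the range is kept wide. For compound 4 the expected value is estimated at 40000 nM, within an estimated range of 12000 nM to 100000 nM.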

Compound 4, half-maximal cytotoxic concentration: 34000 nM
Estimate against measurement, compound 4: 1.2-fold (0.07 log units) above; the range from low to high includes it.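

In this assay, among the compounds shown here, compound 4 gives 34000 nM but compound 3 has no single number, so no step between compound 3 and compound 4 can be read. The compounds shown leave open what 3-fluoro-4-methylphenyl in place of 4-fluorophenyl does to this read-out. No supporting data bear on the result.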